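The source may report more compounds than this note shows. Statements on the series, on what has been measured and on what is new or still open speak of the compounds shown alone.

Measured so far in a functional assay on THP-1 cells (Homo sapiens) for inhibition, read by sulforhodamine B assay, tested at 10 uM; on this read-out lower numbers stand for less inhibition of growth and higher numbers for more inhibition of growth at the one concentration tested:
compound 1 `COc1cc(C2CC(c3ccc([N+](=O)[O-])cc3)=NN2C(C)=O)ccc1OCc1cn(Cc2ccc([N+](=O)[O-])cc2)nn1` gives 7%;
compound 2 `COc1cc(C2CC(c3cc(OC)c(OC)c(OC)c3)=NN2C(C)=O)ccc1OCc1cn(Cc2ccc([N+](=O)[O-])cc2)nn1` gives 29%.

Compound 2 stands highest of these two numbers. Among the compounds with values here, its nearest neighbour is compound 1, and the only measured step is a number 22 percentage points higher from compound 1 to compound 2 (beyond the scatter), which shows that the group on the carbon with a double bond to nitrogen matters here. Compound 3 `COc1ccc(C2=NN(C(C)=O)C(c3ccc(OCc4cn(Cc5ccc([N+](=O)[O-])cc5)nn4)c(OC)c3)C2)cc1` differs from compound 2 by 4-methoxyphenyl in place of 3,4,5-trimethoxyphenyl on a carbon with a double bond to nitrogen. Within the data shown here, no measured step tests this particular exchange, so the one step known gives only indirect guidance: it shows that changing this group can move the result by a modest amount. Since two methoxy groups are lost, a small fall in this assay is expected, close to the scatter. The expected step is a number 11 percentage points lower from compound 2 to compound 3 (beyond the scatter). Compound 3 is therefore estimated at 18%, with a likely range from 3% to 35%.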

Compound 3, percent growth inhibition at one concentration: 8%
Compound 3: middle estimate off by 10 percentage points, on the high side; the range from low to high includes it.
By their numbers in this assay, from the lowest: compounds 1 and 3 (each within the scatter of the next); then compound 2.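

In this assay, the step of a number 21 percentage points lower from compound 2 to compound 3 (beyond the scatter) comes with 4-methoxyphenyl in place of 3,4,5-trimethoxyphenyl, so keeping one methoxy group on this ring does not preserve the higher number of compound 2. Methoxy in place of nitro on an aromatic carbon gives a number 1 percentage points higher from compound 1 to compound 3 (within the scatter), which means the 4-nitrophenyl and 4-methoxyphenyl compounds cannot be told apart here, and among these three compounds only the 3,4,5-trimethoxyphenyl group stands out. Nothing available explains why this group gives more growth inhibition.

On these data alone, it remains open whether a ring with two methoxy groups would keep part of the effect, or whether all three are needed. As far as these compounds go, it is also open how an amine such as dimethylamino or a carboxylic acid on this ring would compare.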